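Dichlorophenyl swap in a series held at the limit

The source may report more compounds than this note shows. Statements on the series, on what has been measured and on what is new or still open speak of the compounds shown alone.

Values in a functional assay on A549 cells (Homo sapiens) for cytotoxicity, read by MTT assay, with a stated time of 72 h (on this read-out lower numbers stand for stronger inhibition and higher numbers for weaker inhibition), so far:
- compound 1 `COc1cccc(/C=C2\CCC/C(=C\c3cccc(Br)c3)C2=O)c1OC` gives > 20000 nM as a limit
- compound 2 `COc1cccc(/C=C2\CCC/C(=C\c3ccc(Br)cc3)C2=O)c1OC` gives > 20000 nM as a limit
- compound 3 `COc1cccc(/C=C2\CCC/C(=C\c3ccc(O)cc3)C2=O)c1OC` gives > 20000 nM as a limit

The standing of compound 3 is the limit of > 20000 nM in this assay, at which 3 of the 3 values shown sit, and no number exists for it. Compound 4 `COc1cccc(/C=C2\CCC/C(=C\c3cccc(Cl)c3Cl)C2=O)c1OC` is the next case, with 2,3-dichlorophenyl in place of 4-hydroxyphenyl on a double-bonded chain carbon bound to a double-bonded ring carbon is the full count of the change.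

Going by the values given here, three measured steps bear on it: a step that the two limits leave unreadable from compound 1 to compound 2, a step that the two limits leave unreadable from compound 1 to compound 3 and a step that the two limits leave unreadable from compound 2 to compound 3, none with a size to carry over. Each compound in these steps stays at a limit, so they offer no direction either. The expected step is a number no higher from compound 3 to compound 4 (the limit leaves the size open) and nothing beyond the scatter is expected from it in this assay, with a report of a limit alone the likeliest result. For compound 4 the estimate is 20000 nM as a value, with an expected range from 9000 nM to 40000 nM in all.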

Compound 4, half-maximal inhibitory concentration: > 20000 nM
Compound 4 ended at the assay's limit; the forecaster's own chance of this, stated with the estimate: 75%; the middle value lies on the limit itself.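

Compound 4 stays at a limit, as do compound 1, compound 2 and compound 3, so none of the steps to compound 4 can be read: the limit of > 20000 nM in this assay, at which 4 of the 4 values shown sit. The compounds shown leave open whether the groups on the double-bonded chain carbon differ at all in this assay.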